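A few compounds are considered here, and "the series" means these few. Any claim that something is new, unique, unknown or untested is made for them only; others in the source may bear on it.

In an ADME assay on BHK cells (Mesocricetus auratus) for cytotoxicity, read by MTT assay, with a stated time of 96 h (on this read-out higher numbers stand for lower toxicity in this test and lower numbers for higher toxicity in this test), compound 3 `COc1ccc(-c2nc3cc(C(F)(F)F)ccc3[nH]2)cc1` gives > 100000 nM, which is a limit of the assay and not a number. Compound 1 `COc1ccc(-c2nc3cc(C(F)(F)F)ccc3[nH]2)c(N)c1` also stands at a limit in this assay, >= 100000 nM. Compound 2 `COc1ccc(-c2nc3cc(C(F)(F)F)ccc3[nH]2)c(OC)c1` likewise reaches only a limit in this assay, > 100000 nM. The steps a step that the two limits leave unreadable from compound 1 to compound 2, a step that the two limits leave unreadable from compound 1 to compound 3 and a step that the two limits leave unreadable from compound 2 to compound 3 thus carry no readable size; the limit of > 100000 nM in this assay, at which 2 of the 3 values shown sit, and the limit of >= 100000 nM in this assay, at which 1 of the 3 values shown sits, account for every value shown on the shared core. Compound 4 `COc1ccc(-c2nc3cc(C(F)(F)F)ccc3[nH]2)c([N+](=O)[O-])c1` differs from compound 3 by nitro in place of hydrogen on an aromatic carbon. Among the compounds with values here, no measured step bears on this change, and all values sit at limits. In this assay the expected step is a number no higher from compound 3 to compound 4 (the limit leaves the size open), within the scatter. Compound 4 is estimated at 100000 nM, between 40000 nM and 250000 nM, most likely again reported as a limit.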

Compound 4, half-maximal cytotoxic concentration: 100000 nM
Estimate against measurement, compound 4: no gap at the digits printed; the measured number falls inside the stated range.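

In this assay compound 4, with nitro on an aromatic carbon ortho to a large group and meta to a methoxy group, gives 100000 nM, the only plain number among the compounds shown, with a number no higher from compound 3 to compound 4 (the limit leaves the size open). The other two steps are a number no higher from compound 2 to compound 4 (the limit leaves the size open) and a number no higher from compound 1 to compound 4 (the limit leaves the size open). The size of each of these steps cannot be read, as each starts from a limit. The other values on the shared core remain limits: the limit of > 100000 nM in this assay, at which 2 of the 4 values shown sit.

Going by these compounds, whether nitro differs at all from hydrogen, methoxy or amino at this position stays open. On these data alone, how a carboxylic acid or a nitrile on the same carbon would read in this assay also stays open.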